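The source may report more compounds than this note shows. Statements on the series, on what has been measured and on what is new or still open speak of the compounds shown alone.

Among the measured compounds shown here, in a functional assay on MCF7 cells (Homo sapiens) for cytotoxicity, read by MTT assay, with a stated time of 48 h (a lower number here means a stronger inhibitor, a higher number a weaker inhibitor), compound 1 `Cc1n[nH]c2c1C(c1ccc(N(C)C)cc1)C(C(=O)NNC(N)=S)=C(N)N2` gives 5210 nM, the lower of the two numbers measured so far. Compound 2 `Cc1n[nH]c2c1C(c1ccc(N(C)C)cc1)C(C(=O)N/N=C1/C(=O)Nc3ccccc31)=C(N)N2` gives 59100 nM, and the gap between them is beyond the scatter. Compound 3 `Cc1n[nH]c2c1C(c1ccc(N(C)C)cc1)C(C(=O)O)=C(N)N2` has not yet been measured. Its difference from compound 1 is this: one oxygen atom in place of a group of 5 heavy atoms (1 carbon, 3 nitrogen, 1 sulfur; no ring), on a carbonyl carbon. The carbonyl carbon stays, and hydroxy now sits on it in place of the whole group that compound 1 carries there.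

For the measured compounds named here, only one measured step bears on this change: an 11-fold higher number from compound 1 to compound 2 (1.05 log units; beyond the scatter). That step is large, but it is indirect evidence. Going by the values given here, it alters the group on the amide-type nitrogen, whereas compound 3 has no such nitrogen, and no measured compound carries hydroxy at this place. It does show that the one replacement measured so far for part of the group in compound 1 raised the number. A higher number is therefore expected here too, an estimated 3.8-fold higher number from compound 1 to compound 3 (0.58 log units; beyond the scatter), though the direction rests on that single step. For compound 3, the estimated value is 20000 nM, with an expected range from 6000 nM to 70000 nM.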

Compound 3, half-maximal inhibitory concentration: 22000 nM
Compound 3: the middle estimate sits 1.1-fold (0.04 log units) below what was measured, within the range that was stated.
By their numbers in this assay, from the lowest: compound 1; then compound 3; then compound 2.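

In this assay, the change at this carbonyl carbon, with hydroxy replacing the whole group that compound 1 carries there, gives a 4.2-fold higher number from compound 1 to compound 3 (0.63 log units; beyond the scatter). Among the compounds shown here, this is the first direct reading at this place, and it shows that the group of compound 1 gives a lower number than hydroxy does, while the printed values place compound 3 at 22000 nM and the larger compound 2 at 59100 nM, so across these three compounds the number does not follow the count of heavy atoms at this place. No measurement offered here accounts for the difference between compound 1 and compound 3.

The compounds shown leave open how a plain primary amide or a methyl ester on the same carbonyl carbon would stand in this assay, and so how much of the group in compound 1 is needed for its lower number. They also leave open whether a group with oxygen in place of the sulfur of compound 1 would keep that number or move towards the value of compound 3.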